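Ring size on the aromatic nitrogen: compound 3 to compound 4

This account rests on a few compounds, and the source may have more. Where it says the series, first, only, none or still open, it means among the compounds named here.

Measured so far in an assay on isolated protein for agonist activity at Bile acid receptor (Homo sapiens), read by TR-FRET; on this read-out lower numbers stand for an effect already at smaller amounts and higher numbers for an effect only at larger amounts of compound:
compound 1 `CCn1c(-c2ccc(OCc3c(-c4c(Cl)cccc4Cl)noc3C(C)C)cc2)nc2ccc(C(=O)O)cc21`: 19.3 nM
compound 2 `CC(C)c1onc(-c2c(Cl)cccc2Cl)c1COc1ccc(-c2nc3ccc(C(=O)O)cc3n2C2CC2)cc1`: 117 nM
compound 3 `CC(C)c1onc(-c2c(Cl)cccc2Cl)c1COc1ccc(-c2nc3ccc(C(=O)O)cc3n2C2CCC2)cc1`: "not determined" (no result reported)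

Going by these compounds, compound 3 stands without a number in this assay, so its place among compound 1 and compound 2 is unknown. Compound 4 `CC(C)c1onc(-c2c(Cl)cccc2Cl)c1COc1ccc(-c2nc3ccc(C(=O)O)cc3n2C2CCCCCC2)cc1` differs from it by cycloheptyl in place of cyclobutyl on an aromatic nitrogen. For the measured compounds named here, one measured step bears on this change: a 6.1-fold higher number from compound 1 to compound 2 (0.78 log units; beyond the scatter). That step put a larger ring on the same aromatic nitrogen and moved the number upward, and compound 4 carries a still larger ring there, so a further move toward higher numbers in this assay is expected, its size uncertain because no value for compound 3 anchors it. Compound 4 is estimated at 500 nM, with a range of 100 nM to 3000 nM.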

Compound 4, half-maximal effective concentration: 113 nM
Compound 4: middle estimate off by 4.4-fold (0.65 log units), on the high side, within the range that was stated.
By their numbers in this assay, from the lowest: compound 1; then compounds 4 and 2 (each within the scatter of the next).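

On this assay, the size of the ring on the aromatic nitrogen makes no readable difference across this span: cycloheptyl in place of cyclopropyl gives a 1.0-fold lower number from compound 2 to compound 4 (0.02 log units; within the scatter). Cycloheptyl in place of ethyl gives a 5.9-fold higher number from compound 1 to compound 4 (0.77 log units; beyond the scatter), so compound 1 with its open ethyl group keeps the lowest number of the three measured compounds. Nothing measured on these compounds accounts for this.

Still open, going by these compounds, is whether a longer chain such as propyl on this nitrogen stays with compound 1 or joins compound 2 and compound 4. Also open, on these data alone, is whether a cycloheptyl ring carrying an amine or a hydroxyl group keeps the number of compound 4.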